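The compounds below may be only part of what the source reports. "The series", "measured", "known", "first", "only" and "open" are said of these compounds alone.

This short series is built on a shared core, a benzene ring carrying two hydroxy groups, and it was tested in a functional assay on HCT-116 cells (Homo sapiens) for cytotoxicity, read by MTT assay, with a stated time of 96 h; a higher number here means a weaker inhibitor, a lower number a stronger inhibitor. Compound 1, `CCOCc1cc(O)c(O)c(Br)c1Br`, carries two bromo groups and an ethoxymethyl group; in this assay compound 1 gives 2510 nM. Among the measured compounds shown here, compound 2, `CCCOCc1cc(O)c(O)c(Br)c1`, carries one bromo group and a propoxymethyl group; in this assay compound 2 gives "not determined" (no result reported), so compound 2 stands nowhere on the scale and no measured step leads away from it. Compound 3, `CCCOCc1cc(O)c(O)c(Br)c1Br`, is still to be measured. The change from compound 2 to compound 3 is bromo in place of hydrogen on an aromatic carbon. With no number for compound 2, the size of this step in this assay cannot be anchored, and no direction beyond the usual scatter can be claimed from the measurements alone. For the measured compounds named here, the only reference point is compound 1, which shares both bromo groups with compound 3. Compound 3 is therefore expected to land at about 2500 nM, within a range of 800 nM to 8000 nM, because compound 1 gives 2510 nM.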

Compound 3, half-maximal inhibitory concentration: 1320 nM
For compound 3 the middle estimate is 1.9-fold (0.28 log units) above the measured one, within the range that was stated.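

In this assay, among the compounds shown here, the one step that can be read is a 1.9-fold lower number from compound 1 to compound 3 (0.28 log units; within the scatter), so with both bromo groups in place, the methyl that turns an ethoxymethyl group into a propoxymethyl group makes no difference that can be told apart from repeat measurement. From the compounds shown here alone, compound 2 has no number on this scale, so the step that adds the second bromo group to the propoxymethyl compounds cannot be read, and what that bromo group contributes on its own stays unknown. Nothing measured here offers a reason for what the chain step shows.

Going by these compounds, one pair of chains is too little to define a trend along the chain, so it remains open whether a longer chain, such as a butoxymethyl group, would still read the same as the ethoxymethyl and propoxymethyl groups. On these data alone, it is also open whether an amine or a carboxylic acid at the end of this chain would move the number beyond the usual spread of repeat measurements.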